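A few compounds are considered here, and "the series" means these few. Any claim that something is new, unique, unknown or untested is made for them only; others in the source may bear on it.

Measured compounds:
compound 1 `COC(=O)[C@@]1(C)CCC=C2[C@@H]1CC[C@@H](C)[C@]2(C)Cc1c[nH]c2ccc(Br)cc12` gives 10000 nM in a functional assay on HeLa cells (Homo sapiens) for inhibition, read by sulforhodamine B assay, with a stated time of 48 h; a higher number here means a weaker inhibitor of growth, a lower number a stronger inhibitor of growth;
compound 2 `COC(=O)[C@@]1(C)CCC=C2[C@@H]1CC[C@@H](C)[C@]2(C)Cc1c[nH]c2ccc(Cl)cc12` gives 11000 nM in this assay.

Compound 2 stands highest of the two numbers shown, yet its nearest neighbour compound 1 lies within the scatter, the step of a 1.1-fold higher number from compound 1 to compound 2 (0.04 log units; within the scatter). Compound 3 `COC(=O)[C@@]1(C)CCC=C2[C@@H]1CC[C@@H](C)[C@]2(C)Cc1c[nH]c2ccc(F)cc12` differs from compound 2 by fluoro in place of chloro on an aromatic carbon. Among the compounds with values here, the only step that bears on this change is the halogen swap from compound 1 to compound 2, which stayed within the scatter, so no step beyond the scatter is expected in this assay for compound 3. The estimate for compound 3 is 11000 nM (range 5000 nM to 25000 nM), an expected step of no change at the digits printed from compound 2 to compound 3 (within the scatter).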

Compound 3, concentration for 50% growth inhibition: 3700 nM
For compound 3 the middle estimate is 3.0-fold (0.47 log units) above the measured one; measured number outside the range, below it.
By their numbers in this assay, from the lowest: compound 3; then compounds 1 and 2 (each within the scatter of the next).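

At this aromatic carbon the choice of halogen does register in this assay: fluoro stands apart from chloro, with a 3.0-fold lower number from compound 2 to compound 3 (0.47 log units; beyond the scatter), and from bromo, with a 2.7-fold lower number from compound 1 to compound 3 (0.43 log units; beyond the scatter), whereas chloro and bromo alone could not be told apart. Compound 3 is thus the strongest growth inhibitor of the three, though the gain is modest. No available measurement accounts for this separation.

As far as these compounds go, whether a nitrile, a methoxy group or an amine at this carbon would match fluoro remains open. So does how the parent with hydrogen there compares.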